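Amide substituent swaps on a shared aminopyrazine ether core

This account rests on a few compounds, and the source may have more. Where it says the series, first, only, none or still open, it means among the compounds named here.

Of the compounds shown here, three sharing one core have been measured in a functional assay on HeLa cells (Homo sapiens) for inhibition, read by MTT assay, with a stated time of 72 h; on this read-out lower numbers stand for stronger inhibition and higher numbers for weaker inhibition. Compound 1 `Cc1noc(C)c1-c1cnc(N)c(Oc2ccc(C(=O)NC3CC3)cc2)n1`, carrying a cyclopropyl group on the amide-type nitrogen, gives 17800 nM. Compound 2 `Cc1noc(C)c1-c1cnc(N)c(Oc2ccc(C(=O)NC3CCCCC3)cc2)n1`, with a cyclohexyl group in that place, gives 26100 nM; the move a 1.5-fold higher number from compound 1 to compound 2 (0.17 log units; within the scatter). Compound 3 `Cc1noc(C)c1-c1cnc(N)c(Oc2ccc(C(=O)Nc3cccc(Cl)c3)cc2)n1`, with a 3-chlorophenyl group on the same nitrogen, gives 1340 nM and is the most potent of the three, since the steps of a 13-fold lower number from compound 1 to compound 3 (1.12 log units; beyond the scatter) and a 19-fold lower number from compound 2 to compound 3 (1.29 log units; beyond the scatter) are both beyond the scatter.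

Compound 4 `Cc1noc(C)c1-c1cnc(N)c(Oc2ccc(C(=O)Nc3cc(Cl)ccn3)cc2)n1` is not yet measured. It differs from compound 3 in one place: 4-chloropyridin-2-yl in place of 3-chlorophenyl on an amide-type nitrogen. Among the measured compounds shown here, no measured pair speaks directly to this change, which keeps an aromatic ring on the amide nitrogen and only exchanges one ring carbon for a nitrogen atom. The two large steps measured so far both concern exchanging a saturated ring for an aromatic one, and they show that this position is sensitive, but they do not tell whether a ring nitrogen helps or hurts. A step within the scatter, in either direction, is therefore the expectation, and the estimated step is a 1.1-fold higher number from compound 3 to compound 4 (0.05 log units; within the scatter). Compound 4 is expected to give about 1500 nM, within a range from 500 nM to 5000 nM in this assay.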

Compound 4, half-maximal inhibitory concentration: 37900 nM
Compound 4: middle estimate off by 25-fold (1.40 log units), on the low side, and the stated range ends below it.
By their numbers in this assay, from the lowest: compound 3; then compounds 1, 2 and 4 (each within the scatter of the next, the first and the last beyond it).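

Having an aromatic ring on the amide-type nitrogen is not enough to give the low number of compound 3: the step of a 28-fold higher number from compound 3 to compound 4 (1.45 log units; beyond the scatter) shows that swapping 3-chlorophenyl for 4-chloropyridin-2-yl, which adds one ring nitrogen and one hydrogen-bond acceptor, can matter as much at this position as replacing a cyclopropyl or cyclohexyl group with 3-chlorophenyl. Compound 4 also fails to stand apart from the compounds with non-aromatic rings, as the steps of a 1.5-fold higher number from compound 2 to compound 4 (0.16 log units; within the scatter) and a 2.1-fold higher number from compound 1 to compound 4 (0.33 log units; beyond the scatter) show, so among these four compounds only compound 3 is clearly separated from all the others. Nothing available here explains why this ring change carries such a large step.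

Going by these compounds, one ring containing nitrogen cannot show whether the location of that nitrogen matters, so it remains open how a chloropyridin-3-yl group would compare with the 3-chlorophenyl group of compound 3. On these data alone, the contribution of the chlorine is also open, and a plain phenyl group or a 3-methoxyphenyl group on the same nitrogen would be the direct comparison with compound 3.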